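Two limits and a 4-hydroxyphenyl analogue

The source may report more compounds than this note shows. Statements on the series, on what has been measured and on what is new or still open speak of the compounds shown alone.

Measured in a functional assay on SK-MEL-28 cells (Homo sapiens) for inhibition, read by colorimetric assay and MTT assay, with a stated time of 72 h; a lower number here means a stronger inhibitor, a higher number a weaker inhibitor:
Compound 1 `COc1ccc(-c2cc(Nc3nnc(-c4ccc(C)cc4)s3)cs2)cc1` gives > 100000 nM as a limit
Compound 2 `Cc1ccc(-c2cc(Nc3nnc(-c4ccc(C)cc4)s3)cs2)cc1` gives > 100000 nM as a limit

Compound 2 stands at > 100000 nM in this assay and this is a limit, not a number. The next compound, compound 3 `Cc1ccc(-c2cc(Nc3nnc(-c4ccc(O)cc4)s3)cs2)cc1`, carries hydroxy in place of methyl on an aromatic carbon, turning 4-methylphenyl into 4-hydroxyphenyl (hydroxy in place of methyl on an aromatic carbon). Within the data shown here, only one measured step exists, a step that the two limits leave unreadable from compound 1 to compound 2, and it gives no size to carry over. It also concerns a different ring from the one changed here. Both measured compounds rest on the same limit (the limit of > 100000 nM in this assay, at which 2 of the 2 values shown sit). Among the measured compounds shown here, the expectation in this assay therefore rests on compound 2 at > 100000 nM alone, with no large step foreseen, and a result at the same limit would be no surprise. The step expected is an at least 1.2-fold lower number from compound 2 to compound 3 (0.09 log units; that floor lies within the scatter) and it is only an estimate. For compound 3 the estimated value is 80000 nM with an expected range from 15000 nM to 200000 nM in this measurement.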

Compound 3, half-maximal inhibitory concentration: 14000 nM
Compound 3: middle estimate off by 5.7-fold (0.76 log units), on the high side, outside the stated range (below it).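

Among these compounds, replacing methyl with hydroxy on this six-membered aromatic ring gives the first readable change in this assay: an at least 7.1-fold lower number from compound 2 to compound 3 (0.85 log units; beyond the scatter). The earlier step between compound 1 and compound 2 cannot be read, so the series showed no sensitivity to any change until this swap of 4-methylphenyl for 4-hydroxyphenyl, which brings in one hydrogen-bond donor and one hydrogen-bond acceptor where methyl had none. The true size of the step remains unknown, and compound 3 is the only compound of the three with a number rather than a limit: the limit of > 100000 nM in this assay, at which 2 of the 3 values shown sit.

The compounds shown leave open whether an amine, a methoxy or a carboxylic acid at this same place would also give a number rather than a limit. They also leave open whether a hydroxy on the other aromatic ring, in place of the methyl of compound 3, would add to this step.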